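This account rests on a few compounds, and the source may have more. Where it says the series, first, only, none or still open, it means among the compounds named here.

Compound 1 `COc1cccc(NC(=O)c2nnn(Cc3ccncc3)c2N)c1` gives 0.7 mL.min-1.g-1
Compound 2 `COc1cccc(NC(=O)c2nnn(CC3CCN(C(C)=O)CC3)c2N)c1` gives 0.7 mL.min-1.g-1
Compound 3 `COc1cccc(NC(=O)c2nnn(Cc3ccc(C(C)C)cc3)c2N)c1` gives 3.2 mL.min-1.g-1

All three values come from an ADME assay on microsomes from liver (Mus musculus, strain CD1) for metabolic stability, read by HPLC, using NADPH, with a stated time of 30 min (on this read-out higher numbers stand for fast clearance and lower numbers for slow clearance), and the compounds differ only in the group on a saturated chain carbon bound to an aromatic nitrogen. Compound 3 stands highest of the three, while the other two show no difference beyond the scatter (no change at the digits printed from compound 1 to compound 2 (within the scatter)).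

The next compound, compound 4 `COc1cccc(NC(=O)c2nnn(Cc3ccc(-n4cccn4)cc3)c2N)c1`, differs from compound 3 in one group (1H-pyrazol-1-yl in place of isopropyl on an aromatic carbon), with 1H-pyrazol-1-yl in place of isopropyl on an aromatic carbon. Among the measured compounds shown here, no measured step makes this exchange directly. The steps of a 4.6-fold higher number from compound 1 to compound 3 (0.66 log units; beyond the scatter) and a 4.6-fold higher number from compound 2 to compound 3 (0.66 log units; beyond the scatter) bear on it only indirectly: each exchanges the whole 4-isopropylphenyl group, and both are modest. Of the three measured compounds, only compound 3 carries the isopropyl group, and it alone gives the higher number. A fall in this assay is therefore expected, though smaller than those two steps, as compound 4 keeps the six-membered aromatic ring of carbon only. The expected change is a 2.1-fold lower number from compound 3 to compound 4 (0.33 log units; beyond the scatter) on this estimate. For compound 4 the estimated value is 1.5 mL.min-1.g-1 with an expected range from 0.7 mL.min-1.g-1 to 3.2 mL.min-1.g-1 in this measurement.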

Compound 4, intrinsic clearance in microsomes: 2.3 mL.min-1.g-1
The estimate for compound 4 lay 1.5-fold (0.19 log units) below the measured number, and the stated range covers the measured number.
By their numbers in this assay, from the lowest: compounds 1 and 2 (each within the scatter of the next); then compounds 4 and 3 (each within the scatter of the next).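

In this assay, the exchange of isopropyl for 1H-pyrazol-1-yl on an aromatic carbon, para to a large group, gives a 1.4-fold lower number from compound 3 to compound 4 (0.14 log units; within the scatter). The earlier compounds shown here left the higher number tied to the isopropyl group, which only compound 3 carried, but here a group with a five-membered aromatic ring, more heavy atoms and hydrogen-bond acceptors takes its place without a change beyond the scatter, and compound 4 gives 2.3 mL.min-1.g-1, while compound 1 gives 0.7 mL.min-1.g-1. The higher number therefore does not need isopropyl at this position, though nothing shown here explains why the number holds across this exchange.

With only isopropyl and 1H-pyrazol-1-yl on this aromatic carbon, the compounds leave open whether any group placed there on the six-membered aromatic ring of carbon only would keep the number with compound 3 and compound 4, or whether it could come down towards compound 1 and compound 2. A carboxylic acid or a morpholine ring at the same place would put that question to a different kind of group.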